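The source may hold more compounds than are shown below. What is called first, only, known or untested is meant among the compounds shown, and "the series" means these compounds.

Compound 3 `CC(=O)Nc1ccc(-c2nc3cc(C(F)(F)F)ccc3n2C)cc1` sits at a limit in an ADME assay on BHK cells (Mesocricetus auratus) for cytotoxicity, read by MTT assay, with a stated time of 96 h (a lower number here means that less compound is tolerated, a higher number that more compound is tolerated), giving > 100000 nM. Compound 1 `Cn1c(-c2ccc([N+](=O)[O-])cc2)nc2cc(C(F)(F)F)ccc21` likewise returns only a limit, > 100000 nM. Compound 2 `Cn1c(-c2ccc(NC(=O)CN3CCCC3)cc2)nc2cc(C(F)(F)F)ccc21` gives a number, 27000 nM. Going by these compounds, because of the limit of > 100000 nM in this assay, at which 2 of the 3 values shown sit, the comparison of compounds 1 and 3 stays open, with a step that the two limits leave unreadable from compound 1 to compound 3. The two readable steps are an at least 3.7-fold lower number from compound 1 to compound 2 (0.56 log units; beyond the scatter) and an at least 3.7-fold higher number from compound 2 to compound 3 (0.56 log units; beyond the scatter), both pointing the same way: the amide bearing a pyrrolidin-1-yl on its chain carbon gives the lower number. Compound 4 `CCN(CC)CC(=O)Nc1ccc(-c2nc3cc(C(F)(F)F)ccc3n2C)cc1` differs from compound 3 by diethylamino in place of hydrogen on a saturated chain carbon bound to a carbonyl carbon, which mirrors, in reverse, the step of an at least 3.7-fold higher number from compound 2 to compound 3 (0.56 log units; beyond the scatter). A lower number of similar size is therefore expected, an at least 2.8-fold lower number from compound 3 to compound 4 (0.45 log units; beyond the scatter). Compound 4 is estimated at 35000 nM, with a range from 12000 nM to 100000 nM.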

Compound 4, half-maximal cytotoxic concentration: 16000 nM
Compound 4: the middle estimate sits 2.2-fold (0.34 log units) above what was measured, and the stated range covers the measured number.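

On the saturated chain carbon bound to a carbonyl carbon, diethylamino in place of hydrogen gives an at least 6.2-fold lower number from compound 3 to compound 4 (0.79 log units; beyond the scatter) in this assay, so the lower number no longer rests on pyrrolidin-1-yl alone. Diethylamino, with no ring, and pyrrolidin-1-yl are not separated here, at a 1.7-fold lower number from compound 2 to compound 4 (0.23 log units; within the scatter), while the swap from nitro gives an at least 6.2-fold lower number from compound 1 to compound 4 (0.79 log units; beyond the scatter). The steps from compounds 1 and 3 stay bounds, not sizes, because of this limit: the limit of > 100000 nM in this assay, at which 2 of the 4 values shown sit.

Still open, going by these compounds, is whether a primary amine, a carboxylic acid or a longer chain between carbonyl and amine on this carbon would give a similar number.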